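Series notes: chloro to trifluoromethyl on the benzylsulfanyl arm

This account rests on a few compounds, and the source may have more. Where it says the series, first, only, none or still open, it means among the compounds named here.

Compound 1 `Cc1cc(S(=O)(=O)/N=C(\N)n2nccc2-c2ccccc2)c(SCc2cccc(Cl)c2)cc1Cl` is the reference point. In an ADME assay on microsomes from liver (Homo sapiens) for metabolic stability, read by LC-MS, using NADPH, tested at 5 uM (on this read-out lower numbers stand for a shorter-lived compound and higher numbers for a longer-lived compound), compound 1 gives 0.309 h. Its number is the top of the three measured, yet the gaps to compound 2 and to compound 3 both fall within the scatter, so the three compounds are not separated by this read-out. Compound 2 `Cc1cccc(CSc2cc(Cl)c(C)cc2S(=O)(=O)/N=C(\N)n2nc(C)cc2-c2ccccc2)c1` gives 0.214 h in this assay, and compound 3 `Cc1cc(-c2ccccc2)n(/C(N)=N/S(=O)(=O)c2cc(C)c(Cl)cc2SCc2cccc(Cl)c2)n1` gives 0.205 h.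

Two single-point steps are available. Methyl in place of hydrogen on an aromatic carbon of the core gives a 1.5-fold lower number from compound 1 to compound 3 (0.18 log units; within the scatter). Chloro in place of methyl on an aromatic carbon gives a 1.0-fold lower number from compound 2 to compound 3 (0.02 log units; within the scatter). Both changes sit on parts of the molecule other than the benzylsulfanyl arm and neither moves the number beyond the scatter.

Compound 4 `Cc1cc(S(=O)(=O)/N=C(\N)n2nccc2-c2ccccc2)c(SCc2cccc(C(F)(F)F)c2)cc1Cl` is the next member. Relative to compound 1 the change is trifluoromethyl in place of chloro on an aromatic carbon. Going by the values given here, no measured step in this set touches the benzylsulfanyl arm or exchanges chloro for trifluoromethyl, so the two steps above bear on it only indirectly, by showing that small peripheral edits left this assay unmoved. On that basis no step beyond the scatter is expected; compound 4 is estimated at 0.3 h, range 0.15 h to 0.6 h, which corresponds to an expected step of a 1.0-fold lower number from compound 1 to compound 4 (0.01 log units; within the scatter).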

Compound 4, half-life: 0.0863 h
Estimate against measurement, compound 4: 3.5-fold (0.54 log units) above; measured number below the stated range.
By their numbers in this assay, from the lowest: compound 4; then compounds 3, 2 and 1 (each within the scatter of the next).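

In this assay the exchange of chloro for trifluoromethyl on the 3-chlorobenzyl group gives a 3.6-fold lower number from compound 1 to compound 4 (0.55 log units; beyond the scatter) and is the first step in the series to lie beyond the scatter, whereas the one edit shown on the shared core, a 1.5-fold lower number from compound 1 to compound 3 (0.18 log units; within the scatter) and so within the scatter, left the read-out unresolved. The same aromatic carbon also carries the methyl-to-chloro change, which gives a 1.0-fold lower number from compound 2 to compound 3 (0.02 log units; within the scatter) on the methylated core, so at this place the read-out separates trifluoromethyl from chloro but does not separate chloro from methyl, though the two comparisons rest on different cores. Nothing measured here accounts for the size of the trifluoromethyl step.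

The compounds shown leave open whether a fluoro, a methoxy or a nitrile at this carbon would stay level with chloro and methyl or track with trifluoromethyl. Also open, going by these compounds, is whether the trifluoromethyl step would recur on the core of compound 3, where the methyl is already in place.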